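Methyl added beside the methylsulfonyl group of compound 2

The source may hold more compounds than are shown below. What is called first, only, known or untested is meant among the compounds shown, and "the series" means these compounds.

Within the data shown here, compound 2 `COc1ccc(S(C)(=O)=O)cc1C(=O)Nc1cccc(-c2nncn2C(C)C)n1` holds the highest of the two numbers so far in an assay for inhibition of high affinity nerve growth factor receptor (Homo sapiens), tested at 1 uM (on this read-out lower numbers stand for less inhibition and higher numbers for more inhibition at the one concentration tested (going by the name of the read-out)), where compound 2 gives 12%. Compound 1 `COc1cc(C)c(S(N)(=O)=O)cc1C(=O)Nc1cccc(-c2nncn2C(C)C)n1` gives -1% in this assay, a gap that lies beyond the scatter. Compound 3 `COc1cc(C)c(S(C)(=O)=O)cc1C(=O)Nc1cccc(-c2nncn2C(C)C)n1` is compound 2 with methyl in place of hydrogen on an aromatic carbon. Among the measured compounds shown here, no measured pair shows this change alone, so its size is unknown. Only a small step is expected, possibly none beyond the scatter. Compound 3 is estimated at 10% with a range of -5% to 25%. The step this estimate means, a number 2 percentage points lower from compound 2 to compound 3 (within the scatter), is expected to stay within the scatter.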

Compound 3, a percentage reported as inhibition, at one concentration (the size of the read-out at that concentration, not a potency): -3%
Estimate against measurement, compound 3: 13 percentage points above; low and high end bracket the measured number.
By their numbers in this assay, from the lowest: compounds 3 and 1 (each within the scatter of the next); then compound 2.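

In this assay, methyl in place of hydrogen on the aromatic carbon ortho to a methylsulfonyl group gives a number 15 percentage points lower from compound 2 to compound 3 (beyond the scatter), so this position responds to even this single added carbon. With that methyl present, methyl in place of amino on a sulfonyl sulfur gives a number 2 percentage points lower from compound 1 to compound 3 (within the scatter), so this pair separates the two sulfonyl groups by no step beyond the scatter. Nothing available bears on why the added methyl lowers the number. As far as these compounds go, whether fluorine or ethyl at this aromatic carbon lowers the number as well remains open. Also open, from the compounds shown here alone, is whether amino on the sulfonyl sulfur matters when the aromatic carbon carries hydrogen.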